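Diphenylpropanamide series: imidazole ring exchanged for benzimidazole

The source may hold more compounds than are shown below. What is called first, only, known or untested is meant among the compounds shown, and "the series" means these compounds.

Measured so far in an assay on ileum with muscarinic acetylcholine receptor M3 (Cavia porcellus) as the target; on this read-out higher numbers stand for weaker inhibition and lower numbers for stronger inhibition:
compound 1 `CC(C)(C)NCCC(c1ccccc1)c1ccccc1` gives 792 nM
compound 2 `CCCc1nccn1CCC(C(N)=O)(c1ccccc1)c1ccccc1` gives 177 nM
compound 3 `CCCc1ncn(CCC(C(N)=O)(c2ccccc2)c2ccccc2)c1CCC` gives 100 nM

Compound 2 holds the second highest of the three numbers. Compound 3 sits nearest, with a lower number that stays within the scatter, so no order between compound 2 and compound 3 can be read from these values. Compound 1 lies furthest away, with a higher number that is beyond the scatter.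

Compound 4 `NC(=O)C(CCn1cnc2ccccc21)(c1ccccc1)c1ccccc1` is the next compound to be measured in this assay. It differs from compound 2 in one place: 1H-benzimidazol-1-yl in place of 2-propyl-1H-imidazol-1-yl on a saturated chain carbon, three bonds along the chain from two aromatic carbons and a carbonyl carbon. Among the measured compounds shown here, no measured pair covers this exchange, so no measured step can be quoted for it. What can be said is that compound 2 and compound 3 carry different substitution on the five-membered ring, and their numbers lie within the scatter of each other. On that basis the step is expected to be small, a 1.4-fold higher number from compound 2 to compound 4 (0.15 log units; within the scatter), if anything toward a higher number, and not clearly beyond the scatter.

For compound 4 the estimate in this assay is 250 nM, with a range from 80 nM to 800 nM.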

Compound 4, antagonist equilibrium constant: 2130 nM
Compound 4: the middle estimate sits 8.5-fold (0.93 log units) below what was measured; the measured number lies above the stated range.
By their numbers in this assay, from the lowest: compounds 3 and 2 (each within the scatter of the next); then compound 1; then compound 4.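

In this assay, this place on the saturated chain carbon does not tolerate every aromatic ring: 1H-benzimidazol-1-yl in place of 2-propyl-1H-imidazol-1-yl gives a 12-fold higher number from compound 2 to compound 4 (1.08 log units; beyond the scatter), which means clearly weaker inhibition. Among the compounds shown here, the counted differences between the two groups are slight, as the entering group adds one heavy atom and keeps the same numbers of hydrogen-bond donors and acceptors and no net charge, so these counts alone give no warning of a step of this size. What does change is that a six-membered aromatic ring of carbon only enters and the propyl group leaves, and no measurement here bears on why the number moves.

For the compounds shown here, both of these changes occur in the one exchange, so their separate shares in the step stay open. Whether the loss follows the added six-membered ring or the missing propyl group remains to be settled by 1H-benzimidazol-1-yl carrying a propyl chain and by 1H-imidazol-1-yl carrying no propyl chain, each on the shared core of compound 2.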